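Swapping chloro for trifluoromethyl on a shared core

The source may hold more compounds than are shown below. What is called first, only, known or untested is meant among the compounds shown, and "the series" means these compounds.

Four compounds share one core. Compound 1 `C/C(=N\O)c1ccc2[nH]c(-c3ccc(Cl)cc3)nc2c1` carries a chloro group, and compound 2 `C/C(=N\O)c1ccc2[nH]c(-c3ccc(C(F)(F)F)cc3)nc2c1` differs from it by trifluoromethyl in place of chloro on an aromatic carbon. Compound 3 `C/C(=N\NC(N)=S)c1ccc2[nH]c(-c3ccc(Cl)cc3)nc2c1` differs from compound 1 by a group of 4 heavy atoms (1 carbon, 2 nitrogen, 1 sulfur; no ring) in place of one oxygen atom, on a double-bonded nitrogen, and compound 4 `C/C(=N\NC(N)=S)c1ccc2[nH]c(-c3ccc(C(F)(F)F)cc3)nc2c1` differs from compound 3 by trifluoromethyl in place of chloro on an aromatic carbon. In an ADME assay on MDBK cells (Bos taurus) for cytotoxicity, read by MTT assay, with a stated time of 96 h (on this read-out lower numbers stand for higher toxicity in this test and higher numbers for lower toxicity in this test), compound 1 gives 37000 nM and compound 2 gives 55000 nM, so a 1.5-fold higher number from compound 1 to compound 2 (0.17 log units; within the scatter). Compound 3 reaches only a limit of the assay, > 100000 nM. The step of an at least 2.7-fold higher number from compound 1 to compound 3 (0.43 log units; beyond the scatter), and this reading rests on (the limit of > 100000 nM in this assay, at which 1 of the 3 values shown sits). The same change that led from compound 1 to compound 2 now leads from compound 3 to compound 4, still to be measured in this assay. The earlier step of a 1.5-fold higher number from compound 1 to compound 2 (0.17 log units; within the scatter) lay within the scatter, and compound 3 already sits at the limit, so for compound 4 a step that the limit leaves unreadable from compound 3 to compound 4 is expected. The estimated value for compound 4 is 150000 nM, expected between 70000 nM and 300000 nM.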

Compound 4, half-maximal cytotoxic concentration: 5000 nM
Estimate against measurement, compound 4: 30-fold (1.48 log units) above, and the stated range ends above it.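

In this assay, trifluoromethyl in place of chloro gives an at least 20-fold lower number from compound 3 to compound 4 (1.30 log units; beyond the scatter), so this change does not carry from the core of compound 1 to the core of compound 3: the same change on two cores in this assay, a 1.5-fold higher number (0.17 log units; within the scatter) from compound 1 to compound 2 and an at least 20-fold lower number (1.30 log units; beyond the scatter) from compound 3 to compound 4, at least 29-fold (1.47 log units) apart, beyond the scatter of two such steps

The other change, the sulfur-containing group in place of oxygen, also depends on its partner, giving an 11-fold lower number from compound 2 to compound 4 (1.04 log units; beyond the scatter): the same change on two cores in this assay, an at least 2.7-fold higher number (0.43 log units; beyond the scatter) from compound 1 to compound 3 and an 11-fold lower number (1.04 log units; beyond the scatter) from compound 2 to compound 4, at least 29-fold (1.47 log units) apart, beyond the scatter of two such steps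

This does not show why the change fails to carry over, nor the true size of the step, since compound 3 gives only a limit and not a number: the limit of > 100000 nM in this assay, at which 1 of the 4 values shown sits.

The compounds shown leave open whether the drop belongs to trifluoromethyl alone. A bromo, methyl or methoxy group in place of chloro on the core of compound 3 could tell.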